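The source may hold more compounds than are shown below. What is called first, only, known or untested is meant among the compounds shown, and "the series" means these compounds.

Measured so far in an ADME assay on HepG2 cells (Homo sapiens) for inhibition, with a stated time of 72 h; on this read-out higher numbers stand for an effect only at larger amounts of compound and lower numbers for an effect already at smaller amounts:
compound 1 `CN(C)CCC(=O)Nc1cccc(-c2nc3ccccc3s2)c1` — 21000 nM
compound 2 `O=C(CCl)Nc1cccc(-c2nc3ccccc3s2)c1` — 16000 nM

Within the data shown here, compound 2 stands at the lower of the two numbers in this assay, with compound 1 as its only neighbour; the step of a 1.3-fold lower number from compound 1 to compound 2 (0.12 log units; within the scatter) lies within the scatter, so the two compounds are not separated on this read-out.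

The next compound is compound 3 `O=C(Nc1cccc(-c2nc3ccccc3s2)c1)c1cnc(Cl)s1`. Relative to compound 2 the change is 2-chloro-1,3-thiazol-5-yl in place of chloromethyl on a carbonyl carbon.

Among the measured compounds shown here, only one measured step exists, a 1.3-fold lower number from compound 1 to compound 2 (0.12 log units; within the scatter), and it concerns a saturated chain carbon bound to the carbonyl carbon, not the carbonyl carbon itself; it was within the scatter. For the measured compounds named here, no measured step touches the carbonyl carbon, and none brings a five-membered aromatic ring into the series at that place, so the change to compound 3 has no direct precedent in the numbers. The expectation for compound 3 in this assay is therefore no step beyond the scatter, a 1.1-fold higher number from compound 2 to compound 3 (0.05 log units; within the scatter), with wide uncertainty. Compound 3 is expected at 18000 nM, with a range from 6000 nM to 55000 nM.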

Compound 3, half-maximal effective concentration: > 25000 nM
Compound 3 ended at the assay's limit; the forecaster's own chance of this, stated with the estimate: 15%; at least 1.3-fold (0.14 log units) between middle value and limit.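

Compound 3 is the one compound in this assay that sits at a limit and not at a number: the limit of > 25000 nM in this assay, at which 1 of the 3 values shown sits.

On the carbonyl carbon whose other neighbour is the amide-type nitrogen, 2-chloro-1,3-thiazol-5-yl in place of chloromethyl gives an at least 1.5-fold higher number from compound 2 to compound 3 (0.19 log units; that floor lies within the scatter), and in place of 2-(dimethylamino)ethyl it gives an at least 1.1-fold higher number from compound 1 to compound 3 (0.07 log units; that floor lies within the scatter). Among these compounds, this is the first reading for a five-membered aromatic ring at this place, and it shows that the ring does not bring the number down in this assay, which the saturated chains of compound 1 and compound 2 could not show. Both floors lie within the scatter, so the change may be small or much larger, and compound 3 is not yet separated from compound 1 or compound 2.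

Still open, as far as these compounds go, is whether the ring itself or the chlorine on it carries the step, which a 1,3-thiazol-5-yl without chlorine on the same carbonyl carbon would address. Also open is whether a phenyl ring or a plain methyl at this place reads any differently from the three compounds shown.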